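The source may report more compounds than this note shows. Statements on the series, on what has been measured and on what is new or still open speak of the compounds shown alone.

Measured compounds in an assay on CHO cells for displacement of a labelled ligand from 5-hydroxytryptamine receptor 1D (Homo sapiens); on this read-out lower numbers stand for stronger inhibition and higher numbers for weaker inhibition:
compound 1 `OC[C@H](NC1CCN(CCCc2c[nH]c3ccc(-n4ccnc4)cc23)CC1)c1ccccc1` gives 0.7 nM
compound 2 `c1cc(CNC2CCN(CCCc3c[nH]c4ccc(-n5cnnc5)cc34)CC2)co1` gives 4.5 nM
compound 3 `OC[C@H](NC1CCN(CCCc2c[nH]c3ccc(Cn4cncn4)cc23)CC1)c1ccccc1` gives 23 nM

Compound 1 has the lowest number of the three. For the measured compounds named here, compound 2 sits nearest to it, and compound 3 furthest; the one single-point step known, a 33-fold higher number from compound 1 to compound 3 (1.52 log units; beyond the scatter), concerns the substituent on the aromatic carbon of the shared core, not the amine substituent.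

Compound 4 `C[C@@H](NC1CCN(CCCc2c[nH]c3ccc(-n4ccnc4)cc23)CC1)c1ccccc1` differs from compound 1 only at the amine: 1-phenylethyl in place of 2-hydroxy-1-phenylethyl on an amine nitrogen. Going by the values given here, no measured pair isolates this change. Compound 2 carries a different amine substituent but also a different aromatic substituent, so its value relative to compound 1 cannot be attributed to either change alone. The amine substituent in compound 4 keeps the phenyl and the stereocentre of compound 1, so the expectation is a small to moderate weakening at most, a 2.1-fold higher number from compound 1 to compound 4 (0.33 log units; beyond the scatter), with a wide range. Compound 4 is therefore estimated at 1.5 nM in this assay, between 0.4 nM and 6 nM.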

Compound 4, half-maximal inhibitory concentration: 4.2 nM
For compound 4 the middle estimate is 2.8-fold (0.45 log units) below the measured one, within the range that was stated.
By their numbers in this assay, from the lowest: compound 1; then compounds 4 and 2 (each within the scatter of the next); then compound 3.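

In this assay, the amine substituent can now be read on its own: with the shared core held constant, 1-phenylethyl in place of 2-hydroxy-1-phenylethyl on an amine nitrogen gives a 6.0-fold higher number from compound 1 to compound 4 (0.78 log units; beyond the scatter). The phenyl ring and one defined stereocentre are present on both sides, while the entering group has no hydrogen-bond donor or acceptor, so the amine substituent joins the aromatic substituent, where the step is a 33-fold higher number from compound 1 to compound 3 (1.52 log units; beyond the scatter), as a place where a single change moves the number beyond the scatter. No available evidence explains the rise in the number.

Going by these compounds, whether the same amine change gives a similar step with (1H-1,2,4-triazol-1-yl)methyl on the aromatic carbon remains open. Also open, on these data alone, is how a methoxy, an amino group or a carboxylic acid in place of the hydroxy group would read in this assay.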